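From 4-methylphenyl to 3-methylphenyl: compound 3 to compound 4

The compounds below may be only part of what the source reports. "The series", "measured", "known", "first", "only" and "open" are said of these compounds alone.

Measured so far in a physicochemical assay for lipophilicity; on this read-out higher numbers stand for higher lipophilicity and lower numbers for lower lipophilicity
Compound 1 `C=CCc1ccc(OC(=O)c2cccc(F)c2)c(OC)c1` – 2.7
Compound 2 `C=CCc1ccc(OC(=O)c2cccnc2)c(OC)c1` – 0.86
Compound 3 `C=CCc1ccc(OC(=O)c2ccc(C)cc2)c(OC)c1` – 2.87

Compound 3 stands at 2.87 and is level, within the scatter, with compound 1, while one gap is large (a number 2.01 log units higher from compound 2 to compound 3 (beyond the scatter)). Compound 4 `C=CCc1ccc(OC(=O)c2cccc(C)c2)c(OC)c1` carries 3-methylphenyl in place of 4-methylphenyl on a carbonyl carbon. Both large steps, the other being (a number 1.84 log units lower from compound 1 to compound 2 (beyond the scatter)), involve pyridin-3-yl, which plays no part in this change. Going by the values given here, the one step without it (a number 0.17 log units higher from compound 1 to compound 3 (within the scatter)) stayed within the scatter, so no step beyond the scatter is expected in this assay here. The expected step is small (a number 0.03 log units higher from compound 3 to compound 4 (within the scatter)). Compound 4 is estimated at 2.9 with an expected range from 2.55 to 3.25 on this read-out.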

Compound 4, partition coefficient: 2.87
Compound 4: middle estimate off by 0.03 log units, on the high side; measured number inside the range.
By their numbers in this assay, from the lowest: compound 2; then compounds 1, 3 and 4 (each within the scatter of the next).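

In this assay, 3-methylphenyl in place of 4-methylphenyl on a carbonyl carbon gives no change at the digits printed from compound 3 to compound 4 (within the scatter), so at this place the two methylphenyl groups cannot be told apart on this read-out. Methyl in place of fluoro on an aromatic carbon gives a number 0.17 log units higher from compound 1 to compound 4 (within the scatter), whereas 3-methylphenyl in place of pyridin-3-yl gives a number 2.01 log units higher from compound 2 to compound 4 (beyond the scatter), so among these four compounds the large steps again occur only with pyridin-3-yl. Nothing shown explains why these steps take these sizes. On these data alone, how a phenyl ring carrying an amine or a carboxylic acid would behave at this place remains open.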